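A larger group on the weaker of two compounds

This account rests on a few compounds, and the source may have more. Where it says the series, first, only, none or still open, it means among the compounds named here.

In a functional assay on HL-60 cells (Homo sapiens) for activation, read by flow cytometry, with a stated time of 4 days (a lower number here means that less compound is needed, a higher number that more compound is needed for the effect), compound 1 (`COc1ccc(-n2cnc3cnc(-c4ccc(F)cc4C)cc32)cc1`) gives 6 nM and compound 2 (`Cc1cc(F)ccc1-c1cc2c(cn1)nc(C)n2-c1ccc(OC(F)F)cc1`) gives 10000 nM as the higher of the two numbers. That gap lies well beyond the usual scatter, so far more of compound 2 is needed for the same effect. The two compounds differ in more than one place, so the gap cannot be tied to any single change.

Compound 3 (`Cc1cc(F)ccc1-c1cc2c(cn1)nc(-c1ccccc1)n2-c1ccc(OC(F)F)cc1`) departs from compound 2 in one place, with phenyl in place of methyl on an aromatic carbon. That carbon lies between two ring nitrogen atoms, next to the ring atom that bears a large group. Within the data shown here, no measured pair shows what such a swap does in this assay so any forecast is loose. It rests on compound 2 at 10000 nM as the starting point, and no step beyond the scatter is expected in either direction. The expected change is a 1.3-fold lower number from compound 2 to compound 3 (0.10 log units; within the scatter) as a rough estimate. The estimate for compound 3 is 8000 nM with an expected range from 1500 nM to 30000 nM in this measurement.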

Compound 3, half-maximal effective concentration in the HL-60 assay: 3800 nM
Estimate against measurement, compound 3: 2.1-fold (0.32 log units) above; the measured number falls inside the stated range.
By their numbers in the HL-60 assay, from the lowest: compound 1; then compound 3; then compound 2.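

In the HL-60 assay, phenyl in place of methyl on this carbon between two ring nitrogen atoms gives a 2.6-fold lower number from compound 2 to compound 3 (0.42 log units; beyond the scatter). Among these compounds, this is the first sign of how this position responds: a much larger group is accepted here, and the number moves down rather than up, by more than the usual scatter. In a physicochemical assay for solubility (a lower number here means a less soluble compound, a higher number a more soluble compound), compound 2 gives 71000 nM and compound 3 gives 6000 nM. In the physicochemical assay the same swap carries a price, a step rated large against the modest one in potency, and this one change is all that separates the two compounds: the measured solubility of compound 2, 71000 nM, and of compound 3, 6000 nM, a 12-fold lower number (1.07 log units; beyond the scatter)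

One swap cannot say whether the size of the phenyl or some other feature of it sets these two steps, nor how an amine, a carboxylic acid or a longer chain on this carbon would fare in either measure. Compound 1 differs from compound 2 and compound 3 in more than one place, so how much of its far lower number depends on this carbon cannot be read from these compounds.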